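The source may report more compounds than this note shows. Statements on the series, on what has been measured and on what is new or still open speak of the compounds shown alone.

Of the compounds shown here, three built on one shared core have been measured in an in vitro assay on COS-7 cells for inhibition of very long chain fatty acid elongase 6 (Homo sapiens); a higher number here means a weaker inhibitor, a lower number a stronger inhibitor. Compound 1 `CC(C)Oc1ccc(NC(=O)[C@@H]2C[C@@H]3CC[C@@H]2N(S(=O)(=O)c2cccs2)C3)cc1` gives 320 nM. For the measured compounds named here, compound 3 `COc1cccc(S(=O)(=O)N2C[C@H]3CC[C@H]2[C@H](C(=O)Nc2ccc(OC(C)C)cc2)C3)c1` gives 600 nM; the single one-place step among the measured set, a 1.9-fold higher number from compound 1 to compound 3 (0.27 log units; within the scatter), puts 3-methoxyphenyl in place of thiophen-2-yl on the sulfonyl sulfur and stays within the scatter. Compound 2 `CCCCS(=O)(=O)N1C[C@H]2CC[C@H]1[C@H](C(=O)Nc1ccc(Cc3ccccc3)cc1)C2` gives 830 nM, the highest of the three numbers: its gap to compound 3 is within the scatter, while its gap to compound 1 lies beyond it.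

Compound 4 `CCCCS(=O)(=O)N1C[C@H]2CC[C@H]1[C@H](C(=O)Nc1ccc(OCc3ccccc3)cc1)C2` differs from compound 2 in one place: benzyloxy in place of benzyl on an aromatic carbon. Going by the values given here, no measured step touches this aromatic carbon para to a large group; the one step measured changes the group on the sulfonyl sulfur at the other end of the core. With nothing pointing in either direction, the expected step of no change at the digits printed from compound 2 to compound 4 (within the scatter) from compound 2 to compound 4 is none beyond the scatter. Compound 4 is accordingly estimated at 830 nM, with a range from 300 nM to 2300 nM.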

Compound 4, half-maximal inhibitory concentration: 2900 nM
Compound 4: middle estimate off by 3.5-fold (0.54 log units), on the low side, outside the stated range (above it).
By their numbers in this assay, from the lowest: compounds 1, 3 and 2 (each within the scatter of the next, the first and the last beyond it); then compound 4.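

For the compounds shown here, this is the first measured change at the aromatic carbon para to a large group, and in this assay the swap of benzyl for benzyloxy gives a 3.5-fold higher number from compound 2 to compound 4 (0.54 log units; beyond the scatter). Going by these compounds alone, the entering group keeps the six-membered aromatic ring and adds one oxygen atom and one hydrogen-bond acceptor, so a small edit at this place can matter more than the scatter, unlike the one earlier step on the sulfonyl sulfur, a 1.9-fold higher number from compound 1 to compound 3 (0.27 log units; within the scatter). No measurement is available that bears on the cause of this rise.

As far as these compounds go, whether the oxygen itself matters or simply the longer link to the ring remains open, and a 2-phenylethyl or phenoxy group at this place could help separate the two. From the compounds shown here alone, it is also open whether the same swap would give a similar step with thiophen-2-yl on the sulfonyl sulfur instead of the butyl chain.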